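The source may hold more compounds than are shown below. What is called first, only, known or untested is meant among the compounds shown, and "the series" means these compounds.

Compound 1 `Fc1ccc(-c2ccc(-c3ccc(-c4nc5ccccc5[nH]4)cc3)cc2)cc1` and compound 2 `Oc1ccc(-c2ccc(-c3ccc(-c4nc5ccccc5[nH]4)cc3)cc2)cc1` share one core and differ in a single group. In a functional assay on PC-3 cells (Homo sapiens) for inhibition, read by sulforhodamine B assay (on this read-out higher numbers stand for weaker inhibition of growth and lower numbers for stronger inhibition of growth), compound 1 gives 41200 nM and compound 2 gives 47000 nM. These two values lie within the scatter of each other, so compound 2 stands level with compound 1 and neither can be ranked above the other.

The next compound, compound 3 `COc1ccc(-c2ccc(-c3ccc(-c4nc5ccccc5[nH]4)cc3)cc2)cc1OC`, changes that same part of the structure: 3,4-dimethoxyphenyl in place of 4-hydroxyphenyl on an aromatic carbon. In words, 3,4-dimethoxyphenyl takes the place of 4-hydroxyphenyl. For the measured compounds named here, no measured pair shows this exact exchange. Going by the values given here, the only guide is a 1.1-fold higher number from compound 1 to compound 2 (0.06 log units; within the scatter), a step within the scatter for a different swap on that ring. One small step is thin evidence, and it does not cover the larger group entering here. The expectation in this assay is therefore no step beyond the scatter, with no firm direction. The expected change is a 1.2-fold lower number from compound 2 to compound 3 (0.07 log units; within the scatter). The estimated value for compound 3 is 40000 nM, with an expected range from 15000 nM to 90000 nM.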

Compound 3, concentration for 50% growth inhibition: 47100 nM
Compound 3: the middle estimate sits 1.2-fold (0.07 log units) below what was measured; low and high end bracket the measured number.
By their numbers in this assay, from the lowest: compounds 1, 2 and 3 (each within the scatter of the next).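

In this assay, 3,4-dimethoxyphenyl in place of 4-hydroxyphenyl gives a 1.0-fold higher number from compound 2 to compound 3 (0.00 log units; within the scatter), and the same group in place of 4-fluorophenyl gives a 1.1-fold higher number from compound 1 to compound 3 (0.06 log units; within the scatter), so all three compounds stand level. The earlier pair covered only a swap of one small group on that ring, whereas here the group at this position gains heavy atoms and goes from 1 hydrogen-bond donor to 0 hydrogen-bond donors, and the number still stays within the scatter. For these three compounds, then, the position takes a larger group with two oxygens without any readable shift in growth inhibition, and no further data are at hand to explain why the numbers stay level.

As far as these compounds go, all three groups are phenyl rings with no net charge, so it remains open whether a group that carries a charge, such as an amine or a carboxylic acid, would move the number beyond the scatter. From the compounds shown here alone, it also remains open whether a longer chain at this position, or a change elsewhere on the shared core, would bring the number down from the level these three compounds share.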